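The source may report more compounds than this note shows. Statements on the series, on what has been measured and on what is new or still open speak of the compounds shown alone.

In an ADME assay on CHO cells (Cricetulus griseus) for cytotoxicity, read by MTT assay, with a stated time of 24 h (a lower number here means that less compound is tolerated, a higher number that more compound is tolerated), compound 1 (`CC1Cn2cc([N+](=O)[O-])nc2O1`) gives > 500000 nM, which is a limit of the assay and not a number. For the measured compounds named here, compound 2 (`CC1Cn2c(nc([N+](=O)[O-])c2C#CC2CC2)O1`) gives 6450 nM, so it holds the only true number so far and cannot yet be ranked among other measured values. Going by the values given here, the one measured step, an at least 77-fold lower number from compound 1 to compound 2 (1.88 log units; beyond the scatter), came with 2-cyclopropylethynyl in place of hydrogen on an aromatic carbon. That step is large, but it records the arrival of the whole group, not a change at its far end.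

Compound 3 (`CC1Cn2c(nc([N+](=O)[O-])c2C#COC2CCCC2)O1`) keeps the triple bond and alters what it carries: cyclopentyloxy in place of cyclopropyl on a triple-bonded carbon. In short, cyclopentyloxy stands in place of cyclopropyl on a triple-bonded carbon. Among the compounds with values here, no measured step covers a swap at this place, so the step from compound 1 gives only weak guidance, and compound 2 at 6450 nM is the natural starting point. No clear shift in either direction is therefore expected, though the uncertainty is wide. The expected step is a 1.1-fold lower number from compound 2 to compound 3 (0.03 log units; within the scatter). For compound 3 the estimated value is 6000 nM, with an expected range from 1500 nM to 30000 nM.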

Compound 3, half-maximal cytotoxic concentration: 6650 nM
Compound 3: the middle estimate sits 1.1-fold (0.04 log units) below what was measured, and the stated range covers the measured number.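

In this assay the swap of cyclopropyl for cyclopentyloxy on a triple-bonded carbon gave a 1.0-fold higher number from compound 2 to compound 3 (0.01 log units; within the scatter) and the two values cannot be told apart. The earlier step could not separate the arrival of the whole group from what sits at its far end, but this pair shows that the far end can take a five-membered ring and an oxygen in place of a three-membered ring with no reading beyond the scatter. The two compounds that carry the triple bond now lie close together and far from compound 1, which stands at a limit and not a number: the limit of > 500000 nM in this assay, at which 1 of the 3 values shown sits.

Going by these compounds, whether this flat result holds for other kinds of group remains open, for the far end has so far carried only a carbon ring, once directly and once through an oxygen, and an amine or a carboxylic acid there could read quite differently. On these data alone, how much of the large step from compound 1 belongs to the triple bond itself is also open, and a simple ethyl group on the same aromatic carbon would be the comparison that speaks to it.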